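A few compounds are considered here, and "the series" means these few. Any claim that something is new, unique, unknown or untested is made for them only; others in the source may bear on it.

Compound 3 `Cc1nnc(SCC(=O)Nc2ccc(-c3nc(-c4ccccc4)c(-c4ccccc4)n3C)cc2)s1` gives 90.5% in a functional assay on HT-29 cells (Homo sapiens) for cytotoxicity, read by MTT assay, with a stated time of 24 h, tested at 80 ug/mL (a lower number here means a weaker effect, a higher number a stronger effect of the compound at the concentration tested), the highest of the three numbers; compound 2 `Cn1c(-c2ccc(NC(=O)CSc3nc4ccccc4s3)cc2)nc(-c2ccccc2)c1-c1ccccc1` gives 82.7% in this assay, and compound 1 `Cn1c(-c2ccc(NC(=O)CSc3nc4cc(Cl)ccc4o3)cc2)nc(-c2ccccc2)c1-c1ccccc1` gives 79.6%. The step of a number 10.9 percentage points higher from compound 1 to compound 3 (beyond the scatter) is the only one beyond the scatter, while a number 7.8 percentage points higher from compound 2 to compound 3 (within the scatter) and a number 3.1 percentage points higher from compound 1 to compound 2 (within the scatter) stay within it. Compound 4 `CN1CCN(CC(=O)Nc2ccc(-c3nc(-c4ccccc4)c(-c4ccccc4)n3C)cc2)CC1` differs from compound 3 in one place: 4-methylpiperazin-1-yl in place of (5-methyl-1,3,4-thiadiazol-2-yl)sulfanyl on a saturated chain carbon bound to a carbonyl carbon. Among the compounds with values here, no measured step removes the sulfur from this saturated chain carbon; all three steps exchange only the ring bound to that sulfur and move the read-out by a modest amount at most. Compound 4 is therefore expected to remain in the same region, with the step of a number 12.5 percentage points lower from compound 3 to compound 4 (beyond the scatter) estimated as small and downward. The estimate for compound 4 in this assay is 78%, between 55% and 95%.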

Compound 4, a percentage reported as activity, at one concentration (the size of the read-out at that concentration, not a potency): 53.1%
The estimate for compound 4 lay 24.9 percentage points above the measured number; the measured number lies below the stated range.
By their numbers in this assay, from the lowest: compound 4; then compounds 1, 2 and 3 (each within the scatter of the next, the first and the last beyond it).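

In this assay, 4-methylpiperazin-1-yl on the saturated chain carbon bound to a carbonyl carbon gives a number 37.4 percentage points lower from compound 3 to compound 4 (beyond the scatter), a number 29.6 percentage points lower from compound 2 to compound 4 (beyond the scatter) and a number 26.5 percentage points lower from compound 1 to compound 4 (beyond the scatter), whichever sulfanyl group it replaces. This position therefore tolerates exchange of the ring on the sulfur far better than replacement of the whole sulfanyl unit. Nothing available accounts for the drop.

The sulfur and the aromatic ring leave together, so the compounds shown do not separate their contributions. A phenylsulfanyl or morpholin-4-yl group at this place would bear on that question.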